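The source may report more compounds than this note shows. Statements on the series, on what has been measured and on what is new or still open speak of the compounds shown alone.

Measured in a functional assay on SK-BR-3 cells (Homo sapiens) for antiproliferative activity, read by MTT assay, with a stated time of 72 h; on this read-out higher numbers stand for weaker inhibition and lower numbers for stronger inhibition:
- compound 1 `CC(Nc1ncnc2ccc(-c3cnn(C4CCNCC4)c3)cc12)c1c(Cl)ccc(F)c1Cl`: 4390 nM
- compound 2 `CC(Nc1ncnc2ncc(-c3cnn(C4CCNCC4)c3)cc12)c1c(Cl)ccc(F)c1Cl`: 17700 nM

Compound 2 has the higher number of the two, which means the weaker inhibition, and its gap to compound 1 lies beyond the scatter. Compound 3 `CC(Nc1ncnc2ncc(-c3cnn(C)c3)cc12)c1c(Cl)ccc(F)c1Cl` carries methyl in place of piperidin-4-yl on an aromatic nitrogen. Going by the values given here, no measured pair shows this change, so the expectation is uncertain. No step beyond the scatter is expected in this assay. The expected change is a 1.1-fold higher number from compound 2 to compound 3 (0.05 log units; within the scatter). For compound 3 the estimated value is 20000 nM, with an expected range of 7000 nM to 50000 nM.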

Compound 3, half-maximal inhibitory concentration: > 100000 nM
Compound 3 ended at the assay's limit; the forecaster's own chance of this, stated with the estimate: 15%; at least 5.0-fold (0.69 log units) between middle value and limit.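

Compound 1 and compound 2 differ only in the core and say nothing about the group on the aromatic nitrogen. Here, methyl in place of piperidin-4-yl gives an at least 5.6-fold higher number from compound 2 to compound 3 (0.75 log units; beyond the scatter) in this assay, so activity in this series depends on the group at this position. The entry for compound 3 is a limit and not a number: the limit of > 100000 nM in this assay, at which 1 of the 3 values shown sits.

Going by these compounds, it remains open whether the ring or its nitrogen matters, which a cyclohexyl group or an open-chain amine such as 2-aminoethyl on the same nitrogen would separate. On these data alone, the same change on the core of compound 1 also remains open.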